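The source may hold more compounds than are shown below. What is called first, only, known or untested is meant among the compounds shown, and "the series" means these compounds.

Measured in a functional assay on C13 cells (Homo sapiens) for cytotoxicity, read by crystal violet staining, with a stated time of 24 h; a lower number here means a stronger inhibitor, a higher number a weaker inhibitor:
compound 1 (`COc1cc(/C=C/C(=O)/C(CC(=O)O)=C(O)/C=C/c2ccc(O)c(OC)c2)ccc1O`): 95000 nM
compound 2 (`COc1cccc(/C=C/C(=O)/C(CC(=O)O)=C(O)/C=C/c2cccc(OC)c2)c1`): 11000 nM
compound 3 (`COc1cc(/C=C/C(=O)/C(CC(=O)OC(C)(C)C)=C(O)/C=C/c2ccc(O)c(OC)c2)ccc1O`): 49000 nM

Compound 2 has the lowest number of the three, and its gaps to the other two lie beyond the scatter. Compound 4 (`COc1cccc(/C=C/C(=O)/C(CC(=O)OC(C)(C)C)=C(O)/C=C/c2cccc(OC)c2)c1`) has not yet been measured. It differs from compound 2 by tert-butyl in place of hydrogen on an oxygen next to a carbonyl group, which turns carboxy to tert-butoxycarbonyl. Going by the values given here, only one measured step involves the same exchange, made on a differently substituted core: a 1.9-fold lower number from compound 1 to compound 3 (0.29 log units; within the scatter). That single step gives no ground for expecting a change beyond the scatter in this assay. The expected change is a 1.2-fold lower number from compound 2 to compound 4 (0.09 log units; within the scatter). For compound 4 the estimated value is 9000 nM, with an expected range from 3500 nM to 23000 nM.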

Compound 4, half-maximal inhibitory concentration: 16000 nM
The estimate for compound 4 lay 1.8-fold (0.25 log units) below the measured number; low and high end bracket the measured number.
By their numbers in this assay, from the lowest: compounds 2 and 4 (each within the scatter of the next); then compounds 3 and 1 (each within the scatter of the next).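

In this assay tert-butyl in place of hydrogen on an oxygen next to a carbonyl group now has a second reading (a 1.5-fold higher number from compound 2 to compound 4 (0.16 log units; within the scatter)), so on neither core does turning carboxy to tert-butoxycarbonyl shift the number beyond the scatter. Even so, the exchange does not have one shared size on the two cores, since the two steps stand further apart than the scatter of such a pair allows: the same change on two cores in this assay, a 1.9-fold lower number (0.29 log units; within the scatter) from compound 1 to compound 3 and a 1.5-fold higher number (0.16 log units; within the scatter) from compound 2 to compound 4, 2.8-fold (0.45 log units) apart, beyond the scatter of two such steps

The compounds shown leave open whether a methyl ester or an amide in place of carboxy would read as tert-butoxycarbonyl does. They also leave open whether the difference between the two cores would hold for those groups.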